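Three Amides Without Liver-Cell Toxicity, and a Fourth

This account rests on a few compounds, and the source may have more. Where it says the series, first, only, none or still open, it means among the compounds named here.

Compound 1 `CCOC(=O)CCCCCOc1cccc(CN(C(=O)c2ccc(-c3cccc(N(C)C)c3)cc2)C(C)C)c1` gives in an ADME assay on HepG2 cells (Homo sapiens) for cytotoxicity, read by CellTiter-Glo and resazurin assay, with a stated time of 72 h (on this read-out higher numbers stand for an effect only at larger amounts of compound and lower numbers for an effect already at smaller amounts), only the limit > 26000 nM.
Compound 2 `CCOC(=O)CCCCCOc1cccc(CN(C(=O)c2ccc(-c3cnc(OC)nc3OC)cc2)C(C)C)c1` gives in this assay only the limit > 26000 nM.
Compound 3 `CCOC(=O)CCCCCOc1cccc(CN(C(=O)c2ccc(-c3ccoc3)cc2)C(C)C)c1` gives in this assay only the limit > 26000 nM.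

The three compounds share one core and differ only in the group attached to an aromatic carbon. None of them reached an effect within the tested range, so that (the limit of > 26000 nM in this assay, at which 3 of the 3 values shown sit). The steps between them are therefore not readable: a step that the two limits leave unreadable from compound 1 to compound 2, a step that the two limits leave unreadable from compound 1 to compound 3 and a step that the two limits leave unreadable from compound 2 to compound 3. Compound 3 thus stands where the other two stand, at the limit of this assay and not at a number.

The next change is 3-methoxyphenyl in place of furan-3-yl on an aromatic carbon, which gives compound 4 `CCOC(=O)CCCCCOc1cccc(CN(C(=O)c2ccc(-c3cccc(OC)c3)cc2)C(C)C)c1`. Within the data shown here, no measured step bears a readable size, and nothing among the three compounds points to an effect that becomes visible at smaller amounts. The step from compound 3 is expected to be none beyond the scatter, written as a step that the limit leaves unreadable from compound 3 to compound 4. Compound 4 is therefore estimated to give about 30000 nM in this assay, most likely again as a limit, within a range from 15000 nM to 100000 nM.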

Compound 4, half-maximal effective concentration: > 21000 nM
Compound 4: no number, only a limit; the forecaster's own chance of this, stated with the estimate: 85%; the middle value does not contradict the limit.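

Compound 4, like compound 1, compound 2 and compound 3, gives only a limit, so none of its steps to those three compounds can be read: the limit of > 21000 nM in this assay, at which 1 of the 4 values shown sits.

The compounds shown leave open at what concentration any of the four would produce an effect in this assay.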